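Compound 4: an Aminophenyl Group Replaces Methoxycarbonylphenyl

The compounds below may be only part of what the source reports. "The series", "measured", "known", "first", "only" and "open" are said of these compounds alone.

Compound 1 `Cc1ccc(C(=O)Nc2cccc(NC(=O)COc3ccc4c(=O)ccoc4c3)c2)cc1`, compound 2 `CCCc1ccc(C(=O)Nc2cccc(NC(=O)COc3ccc4c(=O)ccoc4c3)c2)cc1` and compound 3 `COC(=O)c1ccc(C(=O)Nc2cccc(NC(=O)COc3ccc4c(=O)ccoc4c3)c2)cc1` share one core and differ only in a single group on one aromatic carbon. In an assay on isolated protein for inhibition of Rho-associated protein kinase 2 (Homo sapiens), read by scintillation counting, radiometric assay and 33P incorporation, with a stated time of 40 min, in the presence of a further agent that is not named here (on this read-out higher numbers stand for weaker inhibition and lower numbers for stronger inhibition), compound 1 gives 22 nM, compound 2 gives 14 nM and compound 3 gives 29 nM, the highest of the three numbers. The step of a 1.3-fold higher number from compound 1 to compound 3 (0.12 log units; within the scatter) is small, whereas a 2.1-fold higher number from compound 2 to compound 3 (0.32 log units; beyond the scatter) is modest. Compound 4 `Nc1cccc(C(=O)Nc2cccc(NC(=O)COc3ccc4c(=O)ccoc4c3)c2)c1` carries 3-aminophenyl in place of 4-(methoxycarbonyl)phenyl on a carbonyl carbon. Both measured steps concern substituents on the same aromatic carbon and neither introduces an aminophenyl group, so they bear on this change only loosely; what they do show is that every change so far stayed small. Compound 4 is therefore expected to give 25 nM (range 8 nM to 80 nM). The implied step a 1.2-fold lower number from compound 3 to compound 4 (0.06 log units; within the scatter) is expected to lie within the scatter.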

Compound 4, half-maximal inhibitory concentration: 58 nM
For compound 4 the middle estimate is 2.3-fold (0.37 log units) below the measured one, within the range that was stated.
By their numbers in this assay, from the lowest: compounds 2, 1, 3 and 4 (each within the scatter of the next, the first and the last beyond it).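

Replacing 4-propylphenyl or 4-methylphenyl with 3-aminophenyl on this carbonyl carbon weakens inhibition more than any earlier change: the series shows a 4.1-fold higher number from compound 2 to compound 4 (0.62 log units; beyond the scatter) and a 2.6-fold higher number from compound 1 to compound 4 (0.42 log units; beyond the scatter) with both beyond the scatter. Against 4-(methoxycarbonyl)phenyl the change stays within the scatter, with a 2.0-fold higher number from compound 3 to compound 4 (0.30 log units; within the scatter) as its step. No evidence accompanies these results to account for them. The change replaces the substituent and also its printed ring position, so the two cannot be separated. The compounds shown leave open how 4-aminophenyl or 3-methylphenyl would compare.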